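A few compounds are considered here, and "the series" means these few. Any claim that something is new, unique, unknown or untested is made for them only; others in the source may bear on it.

Measured compounds in this series:

compound 1, `CCc1nc(C(F)(F)F)c2n1CCN([C@@H](C(=O)NC)c1ccccc1)[C@H]2CCc1ccc(C(F)(F)F)cc1`, 11 nM
compound 2, `C=Cc1nc(CC)n2c1C(CCc1ccc(C(F)(F)F)cc1)N([C@@H](C(=O)NC)c1ccccc1)CC2`, 23 nM
compound 3, `CCOc1nc(CC)n2c1C(CCc1ccc(C(F)(F)F)cc1)N([C@@H](C(=O)NC)c1ccccc1)CC2`, 2750 nM

Working notes. The read-out throughout is a functional assay on CHO cells for antagonist activity at Orexin receptor type 2 (Homo sapiens), read by FLIPR and calcium flux; on this read-out higher numbers stand for weaker inhibition and lower numbers for stronger inhibition. Compound 3 stands at the highest number of the three; its nearest neighbour is compound 2, and compound 1 lies furthest from it, both at numbers far below it. Going by the values given here, the one single-site step recorded among the measured compounds is a 120-fold higher number from compound 2 to compound 3 (2.08 log units; beyond the scatter), a large move towards weaker inhibition.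

Compound 4, `CCc1nc(OC)c2n1CCN([C@@H](C(=O)NC)c1ccccc1)C2CCc1ccc(C(F)(F)F)cc1`, is still to be measured. It differs from compound 3 by hydrogen in place of methyl on a saturated chain carbon bound to an oxygen on an aromatic ring: the ethoxy group becomes methoxy.

Among the compounds with values here, the only step that bears on this change is the large one from compound 2 to compound 3, which shows that an alkoxy group at this aromatic carbon goes with a much higher number than vinyl; no step distinguishes one alkoxy from another. Shortening ethoxy to methoxy keeps the oxygen on the ring, so compound 4 is expected to stay near compound 3, with the step of a 1.8-fold lower number from compound 3 to compound 4 (0.26 log units; within the scatter) expected to be small. The estimate for compound 4 in this assay is 1500 nM, with a range from 400 nM to 6000 nM.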

Compound 4, half-maximal inhibitory concentration: 73 nM
Beside the measured number, compound 4's estimate is 21-fold (1.31 log units) above it; the measured number lies below the stated range.
By their numbers in this assay, from the lowest: compound 1; then compound 2; then compound 4; then compound 3.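

In this assay this position responds strongly to a single carbon on the alkoxy chain: ethoxy to methoxy gives a 38-fold lower number from compound 3 to compound 4 (1.58 log units; beyond the scatter), so the two alkoxy groups cannot be treated as equivalent here. Set against vinyl on the same aromatic carbon, methoxy gives only a modest move, a 3.2-fold higher number from compound 2 to compound 4 (0.50 log units; beyond the scatter), whereas ethoxy gave a 120-fold higher number from compound 2 to compound 3 (2.08 log units; beyond the scatter), so an oxygen on the ring does not by itself bring the large rise. No measurement at hand accounts for the gap between methoxy and ethoxy.

Only methoxy and ethoxy represent the alkoxy groups on this aromatic carbon, so the trend with chain length rests on those two points. As far as these compounds go, how a longer chain such as propoxy, or a hydroxyl or an amine in the same place, would read remains open.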